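A few compounds are considered here, and "the series" means these few. Any claim that something is new, unique, unknown or untested is made for them only; others in the source may bear on it.

Compound 1 `O=c1cc(-n2cc(-c3ccccc3)nn2)c2cc(Br)ccc2o1` gives 6660 nM in a functional assay on SW480 cells (Homo sapiens) for antiproliferative activity, read by MTT assay, with a stated time of 48 h; a higher number here means a weaker inhibitor, a lower number a stronger inhibitor; compound 2 `O=c1cc(-n2cc(COc3cccnc3)nn2)c2cc(Br)ccc2o1` gives 39800 nM; compound 3 `O=c1cc(-n2cc(COc3ccccc3Br)nn2)c2cc(Br)ccc2o1` gives 20100 nM.

Compound 2 has the highest number of the three: compound 3 sits within the scatter of it, while compound 1 lies apart, as a 6.0-fold higher number from compound 1 to compound 2 (0.78 log units; beyond the scatter) shows. Compound 4 `O=c1cc(-n2cc(COc3ccc(F)cc3)nn2)c2cc(Br)ccc2o1` differs from compound 2 in one place: 4-fluorophenyl in place of pyridin-3-yl on an oxygen on a saturated carbon. Going by the values given here, the single measured step that bears on this is a 2.0-fold lower number from compound 2 to compound 3 (0.30 log units; within the scatter), where a six-membered aromatic ring of carbon only likewise replaced pyridin-3-yl on the same oxygen, and the number stayed within the scatter. Compound 4 is therefore expected to land close to compound 2, with an estimated 1.7-fold lower number from compound 2 to compound 4 (0.22 log units; within the scatter) and no change beyond the scatter. Compound 4 is estimated at 24000 nM, expected between 9000 nM and 55000 nM.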

Compound 4, half-maximal inhibitory concentration: 1770 nM
For compound 4 the middle estimate is 14-fold (1.13 log units) above the measured one; the whole stated range lies above it.
By their numbers in this assay, from the lowest: compound 4; then compound 1; then compounds 3 and 2 (each within the scatter of the next).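

Going by these compounds alone, at this oxygen on a saturated carbon, the ring attached matters far more than the earlier compounds suggested: in this assay 4-fluorophenyl in place of pyridin-3-yl gives a 22-fold lower number from compound 2 to compound 4 (1.35 log units; beyond the scatter) and 4-fluorophenyl in place of 2-bromophenyl gives an 11-fold lower number from compound 3 to compound 4 (1.06 log units; beyond the scatter) on the same core. Exchanging a ring with a nitrogen for one of carbon only is therefore not enough in itself, since the two carbon-only rings differ sharply here. Nothing available gives a reason for these steps.

The compounds shown leave open whether the fluorine itself or simply the absence of a 2-bromo group carries the gain. A plain phenyl, a 4-chlorophenyl or a 4-methoxyphenyl on this oxygen would bear on that.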